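A few compounds are considered here, and "the series" means these few. Any claim that something is new, unique, unknown or untested is made for them only; others in the source may bear on it.

Three compounds that share one core, each carrying a group on a triple-bonded carbon, have been tested in a functional assay on HeLa cells (Homo sapiens) for antiproliferative activity, read by MTT assay, with a stated time of 72 h; a higher number here means a weaker inhibitor, a lower number a stronger inhibitor. Compound 1, `CC(=O)OCC(CCn1cc(C#Cc2ccc(Br)cc2)c(=O)n(C(=O)c2ccccc2)c1=O)COC(C)=O`, gives 47200 nM in this assay. Compound 2, `CC(=O)OCC(CCn1cc(C#CC2CC2)c(=O)n(C(=O)c2ccccc2)c1=O)COC(C)=O`, gives only > 100000 nM in this assay, which is a limit of the assay rather than a number. Compound 3, `O=c1[nH]c(=O)n(CCC(CO)CO)cc1C#Cc1cc(F)cc(F)c1`, gives 31200 nM in this assay, a number lying within the usual scatter of the number for compound 1, so the two cannot be told apart. Among the compounds with values here, the single measured step in one place, an at least 2.1-fold higher number from compound 1 to compound 2 (0.32 log units; beyond the scatter), exchanged an aromatic group on the triple-bonded carbon for a small saturated ring, and its true size is known only up to the limit of > 100000 nM in this assay, at which 1 of the 3 values shown sits.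

Compound 4, `CCCCCC#Cc1cn(CCC(CO)CO)c(=O)[nH]c1=O`, is not yet measured. It differs from compound 3 in one place: pentyl in place of 3,5-difluorophenyl on a triple-bonded carbon. This change likewise removes an aromatic ring from the triple-bonded carbon and puts a saturated carbon group there. Within the data shown here, the one comparable measured step, an at least 2.1-fold higher number from compound 1 to compound 2 (0.32 log units; beyond the scatter), went toward a weaker inhibitor, so a weaker inhibitor is expected here too, with a fair chance that only a limit is returned. The expected step is a 2.6-fold higher number from compound 3 to compound 4 (0.41 log units; beyond the scatter). Compound 4 is therefore estimated at 80000 nM, with a range from 30000 nM to 200000 nM.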

Compound 4, half-maximal inhibitory concentration: 76300 nM
Estimate against measurement, compound 4: 1.0-fold (0.02 log units) above, and the stated range covers the measured number.
By their numbers in this assay, from the lowest: compounds 3, 1 and 4 (each within the scatter of the next, the first and the last beyond it). At a limit, above all of these: compound 2.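

Putting pentyl in place of 3,5-difluorophenyl on the triple-bonded carbon gives, in this assay, a 2.4-fold higher number from compound 3 to compound 4 (0.39 log units; beyond the scatter). This is the only exchange shown of an aromatic group for a saturated carbon group with a size that can be stated in full, since the earlier exchange of this kind can be bounded on one side only: the limit of > 100000 nM in this assay, at which 1 of the 4 values shown sits. The new step runs in the same direction as the earlier one, on a different pair of compounds, and it shows that a measurable number can still be returned with no ring at all on this carbon.

Two exchanges on two pairs cannot show whether the loss comes from removing the ring or from the particular groups involved, so a plain phenyl on the same side chain as compound 3 would be an informative comparison. As far as these compounds go, it also remains open how a shorter or longer chain than pentyl would behave at this position, or a chain ending in an amine or a carboxylic acid.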